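Bromo for fluoro at the benzylic aryl ring

This account rests on a few compounds, and the source may have more. Where it says the series, first, only, none or still open, it means among the compounds named here.

Measured compounds:
- compound 1 `CC#CCn1c(N2CCC[C@@H](N)C2)cc(=O)n(Cc2ccc(Cl)c(C(=O)O)c2)c1=O`: > 100 nM
- compound 2 `CC#CCn1c(N2CCC[C@@H](N)C2)cc(=O)n(Cc2cccc(C(=O)O)c2Br)c1=O`: "not determined" (no result reported)
- compound 3 `CC#CCn1c(N2CCC[C@@H](N)C2)cc(=O)n(Cc2cc(C(=O)O)ccc2F)c1=O`: > 100 nM

In an assay on isolated protein for inhibition of Dipeptidyl peptidase 9 (Homo sapiens), read by fluorescence, with stated times of 15 min and 20 min (on this read-out higher numbers stand for weaker inhibition and lower numbers for stronger inhibition), compound 3 gives > 100 nM, which is a limit of the assay and not a number. In this assay compound 1 likewise gives > 100 nM, a limit. For compound 2 no result is reported in this assay. Among the compounds with values here, the one step between measured compounds, a step that the two limits leave unreadable from compound 1 to compound 3, is therefore not readable in size; the only evidence on it is the limit of > 100 nM in this assay, at which 2 of the 3 values shown sit.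

Compound 4 `CC#CCn1c(N2CCC[C@@H](N)C2)cc(=O)n(Cc2cc(C(=O)O)ccc2Br)c1=O` differs from compound 3 by bromo in place of fluoro on an aromatic carbon, read one bond further out as 5-carboxy-2-fluorophenyl to 2-bromo-5-carboxyphenyl. Within the data shown here, no measured step covers an exchange of this kind, and the sole measured step is unreadable, so no direction can be taken from the data. Both measured values sit at the limit, and compound 4 is expected to remain in the same region of this assay: the step that the limit leaves unreadable from compound 3 to compound 4 is estimated to stay within the scatter. The estimate for compound 4 in this assay is 300 nM, with a range from 80 nM to 3000 nM, and a report of only a limit is expected to be the most likely outcome.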

Compound 4, half-maximal inhibitory concentration: > 100 nM
Compound 4 gave a limit, no number; the forecaster's own chance of this, stated with the estimate: 75%; the middle value is on the limit's open side.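

In this assay compound 4 gives > 100 nM, a limit of the assay and not a number. Compound 1 and compound 3 also stand at limits, so the steps from each of them to compound 4 cannot be read. The compounds shown leave open whether bromo in place of fluoro changes inhibition at all, and in which direction.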